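Methyl in place of 4-nitrophenyl on the carbonyl carbon

The source may hold more compounds than are shown below. What is called first, only, known or untested is meant among the compounds shown, and "the series" means these compounds.

Of the compounds shown here, three on the shared core have been tested in a functional assay on KB cells (Homo sapiens) for cytotoxicity; on this read-out lower numbers stand for stronger inhibition and higher numbers for weaker inhibition. Compound 1 `COc1ccc(S(=O)(=O)N2CCc3cccc(NS(=O)(=O)c4ccc(F)cc4)c32)cc1` gives 1200 nM. Compound 2 `COc1ccc(S(=O)(=O)N2CCc3cccc(NC(=O)Oc4ccccc4)c32)cc1` gives only a limit of the assay, > 10000 nM, and not a number. Compound 3 `COc1ccc(S(=O)(=O)N2CCc3cccc(NC(=O)c4ccc([N+](=O)[O-])cc4)c32)cc1` gives 102 nM, the lower of the two true numbers, while compound 1 is the nearest at 1200 nM, a gap beyond the scatter.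

Compound 4 `COc1ccc(S(=O)(=O)N2CCc3cccc(NC(C)=O)c32)cc1` is still unmeasured. It differs from compound 3 by methyl in place of 4-nitrophenyl on a carbonyl carbon.

Going by the values given here, two measured steps bear on this change. The step of an at least 8.3-fold higher number from compound 1 to compound 2 (0.92 log units; beyond the scatter) replaces the whole group on the nitrogen. The closer precedent is an at least 98-fold lower number from compound 2 to compound 3 (1.99 log units; beyond the scatter), where 4-nitrophenyl enters on the same carbonyl carbon. Both steps touch the limit of compound 2, so each gives only a minimum size.

Among the measured compounds, only compound 3 carries 4-nitrophenyl, and none carries methyl in that place. A clear rise in this assay is therefore expected on losing that group. The expected step is a 9.8-fold higher number from compound 3 to compound 4 (0.99 log units; beyond the scatter). Compound 4 is estimated at 1000 nM, with an expected range from 200 nM to 6000 nM.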

Compound 4, half-maximal inhibitory concentration: 89 nM
The estimate for compound 4 lay 11-fold (1.05 log units) above the measured number; the whole stated range lies above it.
By their numbers in this assay, from the lowest: compounds 4 and 3 (each within the scatter of the next); then compound 1. At a limit, above all of these: compound 2.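

In this assay, a 1.1-fold lower number from compound 3 to compound 4 (0.06 log units; within the scatter) shows that the 4-nitrophenyl on the carbonyl carbon is not required for the low number: methyl and 4-nitrophenyl read alike at this place, even though the aromatic ring and the nitro-bearing atoms leave. With methyl as the reference, an at least 110-fold lower number from compound 2 to compound 4 (2.05 log units; beyond the scatter) sets phenoxy apart on the same carbonyl carbon, while a 13-fold lower number from compound 1 to compound 4 (1.13 log units; beyond the scatter) sets acetyl apart from (4-fluorophenyl)sulfonyl on the nitrogen on an aromatic ring, so the differences in this small set lie in the phenoxy and sulfonyl compounds and not between the two amides. Compound 2 is held at a limit and not a number, so any step from it gives only a minimum size: the limit of > 10000 nM in this assay, at which 1 of the 4 values shown sits.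

How far this tolerance extends stays open, since the compounds shown hold only methyl and 4-nitrophenyl as carbon groups on this carbonyl. A longer chain such as propyl, an unsubstituted phenyl or a ring bearing a carboxylic acid or an amine could still separate from compound 4 in this assay or read alike with it.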